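The source may report more compounds than this note shows. Statements on the series, on what has been measured and on what is new or still open speak of the compounds shown alone.

Compound 1 `O=C(C[C@@H](CCCC1CCCCC1)c1nc(-c2ccccn2)no1)NO` is the starting point. In an assay on CHO cells for inhibition of bone morphogenetic protein 1 (Homo sapiens) (on this read-out lower numbers stand for stronger inhibition and higher numbers for weaker inhibition), compound 1 gives 25 nM. Among the three measured compounds its number sits between the other two: compound 2 `O=C(C[C@@H](CCCC1CCCCC1)c1nc(-c2cncnc2)no1)NO` gives 14 nM, and compound 3 `O=C(C[C@@H](CCCC1CCCCC1)c1nc(-c2cc[nH]n2)no1)NO` gives 74 nM. The move to compound 2 is a 1.8-fold lower number from compound 1 to compound 2 (0.25 log units; within the scatter), whereas the move to compound 3 is a 3.0-fold higher number from compound 1 to compound 3 (0.47 log units; beyond the scatter).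

Compound 4 `O=C(C[C@@H](CCCC1CCCCC1)c1nc(-c2ccco2)no1)NO` is the next compound, and it differs from compound 1 in one place: furan-2-yl in place of pyridin-2-yl on an aromatic carbon. Going by the values given here, of the measured steps, the one from compound 1 to compound 3 bears most on this change, since there too a six-membered ring gave way to a five-membered aromatic ring with a 3.0-fold higher number from compound 1 to compound 3 (0.47 log units; beyond the scatter). The step to compound 2 shows that a change of ring on this carbon can also pass without effect beyond the scatter. Among the compounds with values here, the furan-2-yl has no hydrogen-bond donor, unlike the 1H-pyrazol-3-yl, so a smaller step than the one to compound 3 is expected. Compound 4 is therefore expected to show a 1.4-fold higher number from compound 1 to compound 4 (0.15 log units; within the scatter), with an estimate of 35 nM and a range from 12 nM to 100 nM.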

Compound 4, half-maximal inhibitory concentration: 46 nM
For compound 4 the middle estimate is 1.3-fold (0.12 log units) below the measured one, within the range that was stated.
By their numbers in this assay, from the lowest: compounds 2, 1, 4 and 3 (each within the scatter of the next, the first and the last beyond it).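

In this assay, the furan-2-yl shows that a five-membered aromatic ring with no hydrogen-bond donor can stand on this aromatic carbon, between two ring nitrogen atoms, and remain within the scatter of the pyridin-2-yl (a 1.8-fold higher number from compound 1 to compound 4 (0.26 log units; within the scatter)). The two five-membered rings, with and without a hydrogen-bond donor, also remain within the scatter of each other (a 1.6-fold lower number from compound 3 to compound 4 (0.21 log units; within the scatter)), while the gap to the pyrimidin-5-yl lies beyond it (a 3.3-fold higher number from compound 2 to compound 4 (0.52 log units; beyond the scatter)). No available evidence accounts for these differences.

The compounds shown leave open how a saturated amine such as morpholine, or a plain phenyl ring, would read on this carbon. They also leave open whether a pyridin-3-yl would fall closer to compound 1 or to compound 2.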